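From 3,4,5-trimethoxyphenyl to 3,5-dimethoxyphenyl: notes on compound 3

This account rests on a few compounds, and the source may have more. Where it says the series, first, only, none or still open, it means among the compounds named here.

For the measured compounds named here, in a functional assay on A549 cells (Homo sapiens) for cytotoxicity, read by MTT assay, with a stated time of 72 h (a lower number here means a stronger inhibitor, a higher number a weaker inhibitor), compound 1 (`COc1cc(/C=C/C(=O)Nc2cc3c(Nc4ccc(F)c(Cl)c4)ncnc3cc2O[C@H]2CCOC2)cc(OC)c1OC`) gives 4150 nM and holds the only number so far. Compound 2 (`COc1cc2ncnc(Nc3ccc(F)c(Cl)c3)c2cc1NC(=O)/C=C/c1cc(OC)c(OC)c(OC)c1`) is reported as "not active" (no number reported) and offers no number for comparison. Compound 3 (`COc1cc(/C=C/C(=O)Nc2cc3c(Nc4ccc(F)c(Cl)c4)ncnc3cc2O[C@H]2CCOC2)cc(OC)c1`) is still to be measured. Its structure departs from that of compound 1 at one place (hydrogen in place of methoxy on an aromatic carbon), with hydrogen in place of methoxy on an aromatic carbon, para to a large group. Going by the values given here, no step between measured compounds shows what this change does in this assay, so no large shift can be argued from the data. The estimated 1.2-fold higher number from compound 1 to compound 3 (0.08 log units; within the scatter) is expected to be slightly weaker and no larger than the scatter. The expected value for compound 3 is 5000 nM with an estimated range from 1800 nM to 15000 nM for repeated measurements.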

Compound 3, half-maximal inhibitory concentration: 10800 nM
Compound 3: the middle estimate sits 2.2-fold (0.33 log units) below what was measured, within the range that was stated.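

In this assay, for the compounds shown here, hydrogen in place of methoxy on the aromatic carbon para to a large group gives a 2.6-fold higher number from compound 1 to compound 3 (0.42 log units; beyond the scatter), the first readable step. The methoxy group at this place, ortho to two methoxy groups, is therefore not neutral in this pair: going from 3,4,5-trimethoxyphenyl to 3,5-dimethoxyphenyl gives a modest loss of potency on a compound that was already weak. No measurement available here accounts for this loss.

One pair cannot show whether the change would have the same size on another version of the shared core. It also leaves open how other groups at this place would compare with methoxy and hydrogen, such as a hydroxyl, an ethoxy group, a fluorine atom or an amine.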